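Ethyl ester versus free acid on two related cinnamate cores

A few compounds are considered here, and "the series" means these few. Any claim that something is new, unique, unknown or untested is made for them only; others in the source may bear on it.

Compound 1 `COc1ccc(/C=C/C(=O)O)c(OC(=O)c2nc(C)c(C)nc2C)c1` and compound 2 `CCOC(=O)/C=C/c1ccc(OC)cc1OC(=O)c1nc(C)c(C)nc1C` share one core; compound 3 `COc1ccc(/C=C/C(=O)O)cc1OC(=O)c1nc(C)c(C)nc1C` and compound 4 `CCOC(=O)/C=C/c1ccc(OC)c(OC(=O)c2nc(C)c(C)nc2C)c1` share another. The difference between the two cores is not broken down here. In a functional assay on EA.hy 926 cells (Homo sapiens) for cytotoxicity, read by MTT assay, with stated times of 24 h and 12 h, tested at 25 uM (a higher number here means a stronger effect of the compound at the concentration tested, a lower number a weaker effect), compound 1 gives -52.1% and compound 2 gives 16.9%, a change of ethyl in place of hydrogen on an oxygen next to a carbonyl group that made a step of a number 69 percentage points higher from compound 1 to compound 2 (beyond the scatter). In this assay compound 3 gives 128%. Compound 4 carries the same change, (ethyl in place of hydrogen on an oxygen next to a carbonyl group). Going by the values given here, for compound 4 a step of a number 18 percentage points lower from compound 3 to compound 4 (beyond the scatter) is expected, smaller than the earlier one, because compound 3 already stands at 128% and the only comparable step, a number 69 percentage points higher from compound 1 to compound 2 (beyond the scatter), comes from a single pair on a different core. Compound 4 is therefore estimated at 110%, between 45% and 165%.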

Compound 4, a percentage reported as activity, at one concentration (the size of the read-out at that concentration, not a potency): 60.1%
Compound 4: the middle estimate sits 49.9 percentage points above what was measured, and the stated range covers the measured number.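

In this assay, putting ethyl in place of the hydrogen of the carboxy group gives a step of a number 67.9 percentage points lower from compound 3 to compound 4 (beyond the scatter). Set beside the earlier pair, the same change moves the read-out in opposite directions: the same change on two cores in this assay, a number 69 percentage points higher (beyond the scatter) from compound 1 to compound 2 and a number 67.9 percentage points lower (beyond the scatter) from compound 3 to compound 4, 136.9 percentage points apart, beyond the scatter of two such steps. The result of this change on one core therefore did not carry over to the other here, but with a single pair per core it does not show why the two differ or how the change would behave on any further core.

The compounds shown leave open whether a longer chain such as propyl, or an amide in place of the ester, would follow either pair. They also leave open which part of the difference between the two cores goes with the direction of the step.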